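The source may hold more compounds than are shown below. What is called first, only, known or untested is meant among the compounds shown, and "the series" means these compounds.

Three compounds in this set have a number, and compound 4 `CCSc1ccccc1C1=NC(c2ccccc2)CO1` is still without one. The value for compound 2 `c1ccc(Oc2ccccc2C2=NC(c3ccccc3)CO2)cc1` in a physicochemical assay for lipophilicity (a lower number here means a more polar compound, a higher number a more lipophilic compound), is 5.61 and stands highest of the three. The nearest number belongs to compound 1 `Clc1ccc(C2=NC(c3ccccc3)CO2)c(Cl)c1`, which in this assay gives 4.4, a gap beyond the scatter. Compound 3 `O=[N+]([O-])c1ccccc1-c1ncco1`, furthest away, gives 1.27 in this assay.

Compound 4 differs from compound 2 in one place: ethylsulfanyl in place of phenoxy on an aromatic carbon.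

Among the measured compounds shown here, no pair of measured compounds in this set shows such a change, so the expected step is a judgement from the structures alone. The expected step of a number 0.91 log units lower from compound 2 to compound 4 (beyond the scatter) is downward and beyond the scatter. Compound 4 is estimated at 4.7, in a range from 4.2 to 5.3.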

Compound 4, partition coefficient: 4.04
Compound 4: middle estimate off by 0.66 log units, on the high side, and the stated range ends above it.
By their numbers in this assay, from the lowest: compound 3; then compound 4; then compound 1; then compound 2.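

On an aromatic carbon ortho to a large group, ethylsulfanyl in place of phenoxy gives the first single-place change read in this assay (a number 1.57 log units lower from compound 2 to compound 4 (beyond the scatter)). This shows that the group at this position can move the read-out by a large amount, even when the count of hydrogen-bond acceptors stays the same. No measurement offered here explains the size of this step.

The compounds shown leave open how an amine, a carboxylic acid or a longer chain at this position would compare. They also leave open whether a ring or the sulfur accounts for the step.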